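The compounds below may be only part of what the source reports. "The series", "measured", "known", "first", "only" and "open" are said of these compounds alone.

Of the compounds shown here, three sharing one core have been measured in an assay on isolated protein for binding affinity to adenosine receptor A1 (Bos taurus); a lower number here means a stronger inhibitor, a higher number a weaker inhibitor. Compound 1 `OCCNc1nc(-c2ccccc2)nc2c1nnn2Cc1ccccc1` gives 38000000 nM, the highest of the three numbers. Compound 2 `CC(O)CNc1nc(-c2ccccc2)nc2c1nnn2Cc1ccccc1Cl` gives 32000000 nM, which lies within the scatter of compound 1. Compound 3 `FC(F)(F)c1ccccc1Cn1nnc2c(NC3CCCCC3)nc(-c3ccccc3)nc21` gives 6800000 nM, a lower number beyond the scatter. Compound 4 `CCCCNc1nc(-c2ccccc2)nc2c1nnn2Cc1ccccc1` has not yet been measured in this assay; it differs from compound 1 by ethyl in place of hydroxy on a saturated chain carbon, two bonds along the chain from a nitrogen on an aromatic ring. Among the measured compounds shown here, no pair of measured compounds isolates this change, so its effect is uncertain. A modest step toward a lower number is nonetheless expected because compound 3 gives 6800000 nM while carrying no hydroxy. The expected step is a 2.5-fold lower number from compound 1 to compound 4 (0.40 log units; beyond the scatter). Compound 4 is estimated at 15000000 nM, with a range from 4000000 nM to 50000000 nM.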

Compound 4, inhibition constant: 11000000 nM
Beside the measured number, compound 4's estimate is 1.4-fold (0.13 log units) above it; low and high end bracket the measured number.
By their numbers in this assay, from the lowest: compounds 3 and 4 (each within the scatter of the next); then compounds 2 and 1 (each within the scatter of the next).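

In this assay, among the compounds shown here, butyl in place of 2-hydroxyethyl gives a 3.5-fold lower number from compound 1 to compound 4 (0.54 log units; beyond the scatter), the first step that isolates a change at this position. Removing the hydroxy, with its hydrogen-bond donor and acceptor, does not raise the number here. No measurement on hand explains this step. The change removes the hydroxy and adds carbon together, so the compounds shown cannot tell these two parts apart. A shorter propyl chain, a longer hexyl chain or an amine at the chain end remains an open comparison.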